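Anilino series on the shared core: weak inhibition so far

The compounds below may be only part of what the source reports. "The series", "measured", "known", "first", "only" and "open" are said of these compounds alone.

Compound 1 `CCc1ccc(NC2=CC(=O)c3c(nc4n3[C@H]3OC[C@@H](O)[C@H]3OC4)C2=O)cc1` gives > 4000 nM in a functional assay on ECa-109 cells for inhibition, with ECa-109 cell line (Homo sapiens) as the target, read by sulforhodamine B assay; a lower number here means a stronger inhibitor, a higher number a weaker inhibitor; this is a limit, not a number.
Compound 2 `CCOc1ccc(NC2=CC(=O)c3nc4n(c3C2=O)[C@H]2OC[C@@H](O)[C@H]2OC4)cc1` gives 3210 nM in this assay.
Compound 3 `CCCN(CCC)C1=CC(=O)c2nc3n(c2C1=O)[C@H]1OC[C@@H](O)[C@H]1OC3` gives > 16000 nM in this assay; this too is a limit.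

Compound 1 stands only at a limit, so its place among the three cannot be fixed; one further value is a limit as well. Compound 4 `COc1cccc(NC2=CC(=O)c3c(nc4n3[C@H]3OC[C@@H](O)[C@H]3OC4)C2=O)c1` differs from compound 1 by 3-methoxyphenyl in place of 4-ethylphenyl on an amine nitrogen. For the measured compounds named here, no step between measured compounds is known, so the size of this change is untested here. The step from compound 1 to compound 4 is expected to remain within the scatter, a step that the limit leaves unreadable from compound 1 to compound 4. Compound 4 is estimated at 5000 nM, between 1500 nM and 16000 nM, with a fair chance that this assay reports only a limit.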

Compound 4, half-maximal inhibitory concentration: 3340 nM
The estimate for compound 4 lay 1.5-fold (0.18 log units) above the measured number, within the range that was stated.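

Placing 3-methoxyphenyl instead of 4-ethylphenyl on the amine nitrogen gives an at least 1.1-fold lower number from compound 1 to compound 4 (0.07 log units; that floor lies within the scatter). In this assay, compound 4 gives a measured number, 3340 nM, so this anilino position can carry a readable value. The true size of the step stays unread because the value of compound 1 is a limit: the limit of > 4000 nM in this assay, at which 1 of the 4 values shown sits.

Still open, on these data alone, is whether a phenyl group bearing an amine or a carboxylic acid would move the number beyond the scatter. A longer chain in place of the methoxy group is equally untested in the compounds shown.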